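The source may hold more compounds than are shown below. What is called first, only, known or untested is meant among the compounds shown, and "the series" means these compounds.

Within the data shown here, compound 3 `O=c1[nH]c2ccccc2n1CCCCN1CCN(C(c2ccccc2)c2ccccc2)CC1` is the only compound of the three with a measured number: in an assay on RPMI-8226 cells for antagonist activity at P2X purinoceptor 7 (Homo sapiens), read by calcium flux (on this read-out lower numbers stand for stronger inhibition and higher numbers for weaker inhibition), compound 3 gives 180 nM. The other two values are limits rather than numbers. Compound 1 `Cc1ccc(S(=O)(=O)N2CCN(CCCn3c(=O)[nH]c4ccccc43)CC2)cc1` reaches only the limit of this assay, > 10000 nM. Compound 2 `O=c1[nH]c2ccccc2n1CCCN1CCN(S(=O)(=O)c2ccc(F)cc2)CC1` likewise shows only the limit, > 10000 nM, in this assay. Among the measured compounds shown here, the single step that joins two measured compounds, from compound 1 to compound 2 with fluoro in place of methyl on an aromatic carbon, is a step that the two limits leave unreadable from compound 1 to compound 2, since both its ends sit at the limit of > 10000 nM in this assay, at which 2 of the 3 values shown sit.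

Compound 4 `Cc1nc2ccccc2n1CCCCN1CCN(C(c2ccccc2)c2ccccc2)CC1` is not yet measured. It differs from compound 3 in one place: a group of 10 heavy atoms (8 carbon, 2 nitrogen; one five-membered aromatic ring with 2 hetero atoms, one six-membered aromatic ring of carbon only) in place of a group of 10 heavy atoms (7 carbon, 2 nitrogen, 1 oxygen; one five-membered aromatic ring with 2 hetero atoms, one six-membered aromatic ring of carbon only), on a saturated chain carbon, four bonds along the chain from an amine nitrogen in a ring. For the measured compounds named here, no measured step touches this part of the molecule, and the only step between measured compounds cannot be read, so the change must be judged without a measured precedent. The exchange keeps the size of the group and its two ring types while altering what the group offers, and a step of modest size toward weaker inhibition is expected, a 2.5-fold higher number from compound 3 to compound 4 (0.40 log units; beyond the scatter), though a result within the scatter would not surprise. Compound 4 is therefore expected to give about 450 nM in this assay, with a range from 120 nM to 3000 nM.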

Compound 4, half-maximal inhibitory concentration: 850 nM
Compound 4: the middle estimate sits 1.9-fold (0.28 log units) below what was measured; low and high end bracket the measured number.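

Among these compounds, the earlier step could not be read, as both its ends are limits, so this is the first readable change, and it falls on the group at the end of the chain, four bonds along the chain from an amine nitrogen in a ring: in this assay there is a 4.7-fold higher number from compound 3 to compound 4 (0.67 log units; beyond the scatter). This position therefore responds to what it carries, yet 2-methyl-1H-benzimidazol-1-yl still leaves compound 4 with a real number and not a limit, so the group that leaves is not the only one that allows measurable inhibition here. Nothing measured in this set explains the size of the step.

The exchange changes more than one thing at once, as the group that leaves has a hydrogen-bond donor and a double bond outside its rings, while the group that enters has neither and carries a methyl, and the compounds shown do not tell these apart. Also open, as far as these compounds go, are what an amine or a hydroxyl in place of that methyl would do, and how a longer chain would act on compound 3.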